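This account rests on a few compounds, and the source may have more. Where it says the series, first, only, none or still open, it means among the compounds named here.

Measured in a functional assay on MOLT-4 cells (Homo sapiens) for antiproliferative activity, read by cell counting, with a stated time of 2 days; a higher number here means a weaker inhibitor, a lower number a stronger inhibitor:
- compound 1 `COc1cc(C(=O)c2sc(N(C)Cc3ccccc3)nc2N)cc(OC)c1OC`: > 200000 nM, a limit of the assay
- compound 2 `COc1cc(C(=O)c2sc(N3CCCC3)nc2N)cc(OC)c1OC`: 260 nM
- compound 3 `COc1cc(C(=O)c2sc(N3CCCCC3)nc2N)cc(OC)c1OC`: 16000 nM

Only two of these results are true numbers, and compound 2 holds the lower one. Compound 3 is its nearest neighbour, with a 62-fold higher number from compound 2 to compound 3 (1.79 log units; beyond the scatter).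

Compound 4 `COc1ccc(C(=O)c2sc(N3CCCC3)nc2N)cc1OC` has hydrogen in place of methoxy on an aromatic carbon of compound 2 (hydrogen in place of methoxy on an aromatic carbon). Among the compounds with values here, no measured step makes this change, so the evidence is indirect. The steps of an at least 760-fold lower number from compound 1 to compound 2 (2.88 log units; beyond the scatter) and an at least 12-fold lower number from compound 1 to compound 3 (1.09 log units; beyond the scatter) exchange a different group, as does the step between compound 2 and compound 3 noted above. All three are large, which shows that a single change can shift this assay strongly within this small set. Compound 2 at 260 nM is already the lowest number, so a rise is the more likely direction, and a step beyond the scatter is expected. The expected change is a 19-fold higher number from compound 2 to compound 4 (1.28 log units; beyond the scatter). For compound 4 the estimated value is 5000 nM, with an expected range from 700 nM to 50000 nM.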

Compound 4, half-maximal inhibitory concentration: 31000 nM
Compound 4: middle estimate off by 6.2-fold (0.79 log units), on the low side; the range from low to high includes it.
By their numbers in this assay, from the lowest: compound 2; then compounds 3 and 4 (each within the scatter of the next). At a limit, above all of these: compound 1.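

The earlier compounds shown here differ only in the amine group on the shared core, so they say nothing about the methoxy groups. In this assay there is a 120-fold higher number from compound 2 to compound 4 (2.08 log units; beyond the scatter) when hydrogen replaces a single methoxy group, ortho to a methoxy group and meta to a large group, which shows that this position matters as well as the amine group. No measurement here bears on why the loss of this methoxy group has so large an effect.

From the compounds shown here alone, it remains open whether ethoxy, hydroxy or a fluorine atom at this place would keep the number close to that of compound 2. Also open, going by these compounds, is whether the same replacement would have a step of similar size in compound 3, which carries piperidin-1-yl.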